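Smaller ester group on the shared core: cytotoxicity expected unchanged

This account rests on a few compounds, and the source may have more. Where it says the series, first, only, none or still open, it means among the compounds named here.

Compound 2 `CC(C)(C)OC(=O)C(O)Cn1cnc2c(N)ncnc21` is one of two compounds of the same core examined in a functional assay on HeLa cells (Homo sapiens) for cytotoxicity; a lower number here means that less compound is tolerated, a higher number that more compound is tolerated. In this assay compound 2 gives > 400 ug/mL, which is a limit of the assay and not a number. Compound 1 `COCCOC(=O)C(O)Cn1cnc2c(N)ncnc21` likewise gives > 400 ug/mL, again a limit. Within the data shown here, the only measured step, a step that the two limits leave unreadable from compound 1 to compound 2, touches the same oxygen next to a carbonyl group. Both values sit at the limit of > 400 ug/mL in this assay, at which 2 of the 2 values shown sit. Compound 3 `CCOC(=O)C(O)Cn1cnc2c(N)ncnc21` has not yet been measured. Compared with compound 2 it carries ethyl in place of tert-butyl on an oxygen next to a carbonyl group. The measured step at this position gives no readable size, and no measured compound in this set has shown a number below the limit. For this assay the step of a number no higher from compound 2 to compound 3 (the limit leaves the size open) is therefore expected to stay within the scatter. Compound 3 is expected most likely to be reported only as a limit again, and is estimated at 400 ug/mL, between 200 ug/mL and 800 ug/mL.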

Compound 3, minimum cytotoxic concentration: > 400 ug/mL
Compound 3 gave a limit, no number; the forecaster's own chance of this, stated with the estimate: 85%; the middle value sits exactly at the limit.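

No step among compound 1, compound 2 and compound 3 can be read in this assay, where each result is a limit and not a number: the limit of > 400 ug/mL in this assay, at which 3 of the 3 values shown sit.

The compounds shown leave open whether the 2-methoxyethyl, tert-butyl and ethyl esters differ at all in this assay.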